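Benzyl for Acetyl on a Ring Nitrogen: Compound 4

The source may report more compounds than this note shows. Statements on the series, on what has been measured and on what is new or still open speak of the compounds shown alone.

Three compounds have been measured in an assay for binding affinity to adenosine receptor A1 (Bos taurus); on this read-out higher numbers stand for weaker inhibition and lower numbers for stronger inhibition:

Compound 1 `Cc1ccc2c(NN)c(Cc3ccccc3)cnc2n1` gives 220 nM.
Compound 2 `Cc1ccc2c(O)c(C(=O)NCc3ccc(NC(=O)c4ccccc4)cc3)cnc2n1` gives 7590 nM.
Compound 3 `CC(=O)Nc1ccc2c(O)c(C(=O)NCc3ccccc3)cnc2n1` gives > 10000 nM.

Among the compounds with values here, compound 3 is the weakest of the three: its reading of > 10000 nM is a limit of the assay, not a number, and it is the one value that sits at the limit of > 10000 nM in this assay, at which 1 of the 3 values shown sits. Compound 1 shows the lowest number of the set, compound 2 a high one.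

Compound 4 `O=C(NCc1ccccc1)c1cnc2nc(NCc3ccccc3)ccc2c1O` differs from compound 3 in one place: benzyl in place of acetyl on a nitrogen on an aromatic ring. Within the data shown here, no pair among the three measured compounds shows this exact change, so no measured step tells how large its effect is. Among the measured compounds shown here, compound 1 also carries a benzyl group, but it differs from compound 3 in other places too, so the two values show only that compound 1 sits far lower. Since compound 3 starts from a limit, the step from compound 3 to compound 4 is expected to be an at least 2.5-fold lower number from compound 3 to compound 4 (0.39 log units; beyond the scatter), toward stronger binding, with little certainty. Compound 4 is therefore estimated at 4000 nM, expected to lie between 800 nM and 20000 nM.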

Compound 4, inhibition constant: 677 nM
Beside the measured number, compound 4's estimate is 5.9-fold (0.77 log units) above it, outside the stated range (below it).
By their numbers in this assay, from the lowest: compound 1; then compound 4; then compound 2. At a limit, above all of these: compound 3.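

In this assay, replacing acetamido with benzylamino gives an at least 14-fold lower number from compound 3 to compound 4 (1.16 log units; beyond the scatter), so the group on this nitrogen on an aromatic ring has a large bearing on binding. The change removes a carbonyl and the hydrogen-bond acceptor counted with it, and adds a six-membered aromatic ring of carbon only, and together these go with much stronger binding. The true size of the step remains unknown, because the reading for compound 3 is a limit of the assay and not a number: the limit of > 10000 nM in this assay, at which 1 of the 4 values shown sits.

Since the carbonyl leaves as the aromatic ring enters, the compounds shown cannot tell whether the gain comes from losing the one or gaining the other. A free amine or a phenethyl group, with its longer chain, on this nitrogen would help to separate those two parts of the change.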